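The source may report more compounds than this note shows. Statements on the series, on what has been measured and on what is new or still open speak of the compounds shown alone.

For the measured compounds named here, compound 1 `CCCCCCCCCCO[C@H]1C=C(COC(C)=O)C(=O)[C@@H]2O[C@@](C)(OC)[C@](C)(OC)O[C@@H]12` is the only compound of the series with a numbered read-out in an assay on isolated protein for inhibition of glutathione S-transferase A2 (Homo sapiens), read by spectrophotometry, with a stated time of 3 min (a lower number here means a stronger inhibitor, a higher number a weaker inhibitor), where compound 1 gives 33100 nM. Compound 2 `CC(=O)OCC1=C[C@H](O)[C@H](O)[C@@H](O)C1=O` reaches only a limit in this assay, reported as > 100000 nM, so that the limit of > 100000 nM in this assay, at which 1 of the 2 values shown sits, describes where it sits. Compound 3 `CO[C@]1(C)O[C@H]2[C@@H](OC/C=C/c3ccccc3)C=C(COC(C)=O)C(=O)[C@@H]2O[C@@]1(C)OC` carries 2-phenylethenyl in place of nonyl on a saturated chain carbon bound to an oxygen on a saturated carbon relative to compound 1. Going by the values given here, no measured step between compounds is available to set a scale for this change, so a step no larger than the scatter is expected from compound 1 to compound 3, a 1.1-fold lower number from compound 1 to compound 3 (0.04 log units; within the scatter), in either direction. Compound 3 is therefore estimated at 30000 nM in this assay, in a range from 8000 nM to 100000 nM.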

Compound 3, half-maximal inhibitory concentration: 94200 nM
Compound 3: middle estimate off by 3.1-fold (0.50 log units), on the low side, within the range that was stated.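

In this assay, for the compounds shown here, the saturated chain carbon bound to an oxygen on a saturated carbon responds to the group it carries: 2-phenylethenyl in place of nonyl gives a 2.8-fold higher number from compound 1 to compound 3 (0.45 log units; beyond the scatter), the only measured step. Both groups count no hydrogen-bond donors or acceptors, so the step comes without a change in those counts. No measurement shown accounts for this step.

Still open, as far as these compounds go, is how a longer chain, a saturated 2-phenylethyl group or an amine would read at this position.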